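The source may hold more compounds than are shown below. What is called first, only, known or untested is meant among the compounds shown, and "the series" means these compounds.

Compound 1 `Cn1nc2c(=O)n(CC3(O)CCN(Cc4ccc(-c5ccco5)cc4Cl)CC3)cnc2c1-c1ccc(C2(N)CC2)cc1` gives 66.1 nM in an assay on isolated protein for inhibition of ubiquitin carboxyl-terminal hydrolase 7 (Homo sapiens), with stated times of 30 min and 2 h; on this read-out lower numbers stand for stronger inhibition and higher numbers for weaker inhibition. Compound 2 `CCCNCc1ccc(-c2c3ncn(CC4(O)CCN(Cc5ccc(-c6ccco6)cc5Cl)CC4)c(=O)c3nn2C)cc1`, with (propylamino)methyl in place of 1-aminocyclopropyl on an aromatic carbon, gives 43.9 nM in this assay. On these two numbers compound 2 and compound 1 sit within the scatter of each other, so neither stands apart. Compound 3 `Cn1nc2c(=O)n(CC3(O)CCN(Cc4ccc(-c5ccco5)cc4Cl)CC3)cnc2c1-c1ccc(C(=N)N)cc1` changes the same place again: a group of 3 heavy atoms (1 carbon, 2 nitrogen; no ring) in place of a group of 5 heavy atoms (4 carbon, 1 nitrogen; no ring), on an aromatic carbon. Among the measured compounds shown here, the only measured step that bears on it is a 1.5-fold lower number from compound 1 to compound 2 (0.18 log units; within the scatter), which exchanged the group at this aromatic carbon and moved the number within the scatter only. One step is thin ground, but it gives no reason to expect a move beyond the scatter in this assay in either direction. Compound 3 is therefore expected to give 55 nM, with a range of 20 nM to 160 nM, an estimated step of a 1.3-fold higher number from compound 2 to compound 3 (0.10 log units; within the scatter).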

Compound 3, half-maximal inhibitory concentration: 87.5 nM
Estimate against measurement, compound 3: 1.6-fold (0.20 log units) below; measured number inside the range.
By their numbers in this assay, from the lowest: compounds 2, 1 and 3 (each within the scatter of the next).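

Compound 3 puts a group of 3 heavy atoms (1 carbon, 2 nitrogen) with a double bond outside the aromatic rings on this aromatic carbon, para to a large group, and in this assay the two new steps are a 2.0-fold higher number from compound 2 to compound 3 (0.30 log units; within the scatter) and a 1.3-fold higher number from compound 1 to compound 3 (0.12 log units; within the scatter). Across compounds 1, 2 and 3, then, three groups of different size and shape, with and without a ring, all stay within the scatter of one another, where earlier only a single exchange spoke to this. No measurement shown offers a reason for this flat reading.

All three groups carry nitrogen, so a carboxylic acid, a methyl or a plain hydrogen at this carbon remains an open test. From the compounds shown here alone, whether a longer amine chain than (propylamino)methyl would move the number beyond the scatter also remains open.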